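Extending the unsaturated amide chain in the shared core

This account rests on a few compounds, and the source may have more. Where it says the series, first, only, none or still open, it means among the compounds named here.

Compound 1 `C/C=C/C(=O)Nc1cccc(Oc2nc(Nc3cccc(C#N)c3)nc3ccsc23)c1` gives 33100 nM in a functional assay on MCF7 cells (Homo sapiens) for inhibition, read by MTT assay, with a stated time of 72 h; on this read-out higher numbers stand for weaker inhibition and lower numbers for stronger inhibition. Compound 2 `CC(C)=CC(=O)Nc1cccc(Oc2nc(Nc3cccc(C#N)c3)nc3ccsc23)c1` gives 41100 nM in this assay. Compound 3 `CC/C=C/C(=O)Nc1cccc(Oc2nc(Nc3cccc(C#N)c3)nc3ccsc23)c1` returns only a limit of the assay, > 50000 nM, in this assay.

On these numbers compound 3 stands at the limit of this assay, not at a measured value, and all three compounds sit in the weak range. Compound 4 `CCC/C=C/C(=O)Nc1cccc(Oc2nc(Nc3cccc(C#N)c3)nc3ccsc23)c1` differs from compound 3 by methyl in place of hydrogen on a saturated chain carbon, two bonds along the chain from a double-bonded chain carbon. Among the compounds with values here, the steps that bear on this change are the ones along the same chain: an at least 1.5-fold higher number from compound 1 to compound 3 (0.17 log units; that floor lies within the scatter) and an at least 1.2-fold higher number from compound 2 to compound 3 (0.08 log units; that floor lies within the scatter), both of them resting on the limit, and the lateral comparison a 1.2-fold higher number from compound 1 to compound 2 (0.09 log units; within the scatter), which is within the scatter. Every measured step along this chain therefore reads as no change beyond the scatter, with compound 3 already at the limit of > 50000 nM in this assay, at which 1 of the 3 values shown sits. Compound 4 is therefore expected to show a step that the limit leaves unreadable from compound 3 to compound 4, that is, no movement beyond the scatter and most likely another limit. The estimate for compound 4 in this assay is 65000 nM, with a range from 30000 nM to 150000 nM.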

Compound 4, half-maximal inhibitory concentration: 49100 nM
Compound 4: middle estimate off by 1.3-fold (0.12 log units), on the high side; the range from low to high includes it.
By their numbers in this assay, from the lowest: compounds 1, 2 and 4 (each within the scatter of the next). At a limit, above all of these: compound 3.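

Compound 4, with pent-1-en-1-yl on the carbonyl carbon, gives a measured value in this assay, so this chain now has a number at a length where compound 3 gave none. Both steps between measured numbers lie within the scatter (a 1.2-fold higher number from compound 2 to compound 4 (0.08 log units; within the scatter)) (a 1.5-fold higher number from compound 1 to compound 4 (0.17 log units; within the scatter)), so neither the pent-1-en-1-yl in place of 2-methylprop-1-en-1-yl nor the ethyl in place of hydrogen separates from compound 1 or compound 2 on this read-out. Compound 3 remains a limit of the assay. The remaining step (an at least 1.0-fold lower number from compound 3 to compound 4 (0.00 log units; that floor lies within the scatter)) rests on that limit, and its floor is all that it shows: the limit of > 50000 nM in this assay, at which 1 of the 4 values shown sits.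

The compounds shown leave open whether a longer chain on the carbonyl carbon would move the number beyond the scatter. They also leave open what an amine or a carboxylic acid at the end of this chain would do.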